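The source may report more compounds than this note shows. Statements on the series, on what has been measured and on what is new or still open speak of the compounds shown alone.

Working notes on the series, step from compound 2 to compound 4.

In a functional assay on SK-LU-1 cells (Homo sapiens) for antiproliferative activity, read by sulforhodamine B assay, with a stated time of 48 h, tested at 50 uM (on this read-out lower numbers stand for less inhibition and higher numbers for more inhibition at the one concentration tested (going by the name of the read-out)), compound 1 `COc1ccc(C(=O)Oc2cc3c(cc2C)[C@@H](C(C)C)CC=C3C)cc1` gives 18.6%, compound 2 `COc1cccc(C(=O)Oc2cc3c(cc2C)[C@@H](C(C)C)CC=C3C)c1` gives 24.2%, and compound 3 `CC1=CC[C@H](C(C)C)c2cc(C)c(OC(=O)c3ccc([N+](=O)[O-])cc3)cc21` gives 47.5%. Compound 2 stands second highest of the three numbers: its nearest neighbour is compound 1, with a number 5.6 percentage points higher from compound 1 to compound 2 (within the scatter), a gap within the scatter, so no order between compound 1 and compound 2 is claimed; its furthest neighbour is compound 3, with a number 23.3 percentage points higher from compound 2 to compound 3 (beyond the scatter), a gap beyond the scatter.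

Compound 4 `CC1=CC[C@H](C(C)C)c2cc(C)c(OC(=O)c3cccc(C(F)(F)F)c3)cc21` is not yet measured in this assay. It differs from compound 2 by trifluoromethyl in place of methoxy on an aromatic carbon. Among the measured compounds shown here, no measured step replaces methoxy with trifluoromethyl. For the measured compounds named here, the steps that bear on it are the replacements of methoxy on the aromatic ring by another group: a number 28.9 percentage points higher from compound 1 to compound 3 (beyond the scatter) and a number 23.3 percentage points higher from compound 2 to compound 3 (beyond the scatter), both modest rises beyond the scatter, whereas moving the methoxy between positions, a number 5.6 percentage points higher from compound 1 to compound 2 (within the scatter), stayed within the scatter. With only the nitro replacement as a guide, a rise in this assay is expected, but a smaller one, since trifluoromethyl is not nitro.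

Compound 4 is therefore estimated at 32% in this assay, with a range from 18% to 48%, an expected step of a number 7.8 percentage points higher from compound 2 to compound 4 (within the scatter).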

Compound 4, a percentage reported as inhibition, at one concentration (the size of the read-out at that concentration, not a potency): 18.3%
Beside the measured number, compound 4's estimate is 13.7 percentage points above it, within the range that was stated.
By their numbers in this assay, from the lowest: compounds 4, 1 and 2 (each within the scatter of the next); then compound 3.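

In this assay, putting trifluoromethyl in place of methoxy on this aromatic carbon, meta to a large group, gives a number 5.9 percentage points lower from compound 2 to compound 4 (within the scatter), so this exchange cannot be told apart from the scatter. The earlier compounds shown here showed a replacement of methoxy only with nitro, as in a number 23.3 percentage points higher from compound 2 to compound 3 (beyond the scatter); compound 4 now shows that losing the methoxy does not by itself bring a rise beyond the scatter, and within these four compounds only compound 3, the 4-nitrophenyl ester, stands apart from the rest. Nothing available accounts for this difference between the two replacements.

It remains open whether the higher number of compound 3 belongs to the nitro group itself or to where that group sits on the ring, as the compounds shown offer no pair that separates the two. Also open, going by these compounds, is how this same aromatic carbon responds to a group of another kind, such as an amine, a carboxylic acid or a nitrile, which would show whether compound 3 stays alone in this assay.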